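Cytotoxicity on MT4 cells: swapping the anilino ring

The source may hold more compounds than are shown below. What is called first, only, known or untested is meant among the compounds shown, and "the series" means these compounds.

Two compounds have been examined in a toxicity assay on MT4 cells (Homo sapiens) for cytotoxicity, read by MTT assay, with a stated time of 5 days; a lower number here means that less compound is tolerated, a higher number that more compound is tolerated. Compound 1 `Cc1cc(-c2ccc(C#N)cc2)cc(C)c1Oc1nc(Nc2ccc(C#N)nc2)nc2ccsc12` gives 214000 nM, while compound 2 `Cc1cc(-c2ccc(F)cc2)cc(C)c1Oc1nc(Nc2ccc(C#N)c(F)c2)nc2ccsc12` gives 97300 nM. Going by the values given here, of these two numbers compound 2 stands lowest, and its gap to compound 1 lies beyond the scatter; the two compounds differ in more than one place, so no single step connects them.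

Compound 3 `Cc1cc(-c2ccc(F)cc2)cc(C)c1Oc1nc(Nc2ccc(C#N)nc2)nc2ccsc12` has not yet been measured. It arises from compound 2 by one change: 6-cyanopyridin-3-yl in place of 4-cyano-3-fluorophenyl on a nitrogen on an aromatic ring. The group that enters is the same 6-cyanopyridin-3-yl that compound 1 carries on a nitrogen on an aromatic ring, although compound 1 also differs from compound 3 elsewhere, so its number cannot be read directly across.

Among the compounds with values here, with no measured step of this kind to rest on, compound 3 is expected to move only modestly upward from compound 2 in this assay, by a step of a 1.5-fold higher number from compound 2 to compound 3 (0.19 log units; within the scatter), which may well remain within the scatter. The estimate for compound 3 is therefore 150000 nM, with a range from 70000 nM to 300000 nM.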

Compound 3, half-maximal cytotoxic concentration: 6130 nM
Beside the measured number, compound 3's estimate is 24-fold (1.39 log units) above it, and the stated range ends above it.
By their numbers in this assay, from the lowest: compound 3; then compound 2; then compound 1.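

Swapping in 6-cyanopyridin-3-yl for 4-cyano-3-fluorophenyl on a nitrogen on an aromatic ring gives a 16-fold lower number from compound 2 to compound 3 (1.20 log units; beyond the scatter) in this assay and shows that this place strongly affects how much compound is tolerated. With 6-cyanopyridin-3-yl held fixed, fluoro in place of cyano on an aromatic carbon gives a 35-fold lower number from compound 1 to compound 3 (1.54 log units; beyond the scatter) as well, so a second place also moves the number by a large step. Both steps lie beyond the scatter and both end at compound 3, the lowest of the three, and nothing measured here offers a reason for either step.

The swap on the nitrogen exchanges one ring for another and removes the fluorine in the same step, so the compounds shown do not tell which part of the change carries the drop, and a plain 4-cyanophenyl on that nitrogen would be needed to separate the two. Also open, going by these compounds, is how an amine or a carboxylic acid in place of the fluoro on the aromatic carbon would read, since only fluoro and cyano appear there.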